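The compounds below may be only part of what the source reports. "The series", "measured", "known", "first", "only" and "open" are said of these compounds alone.

Measured compounds:
- compound 1, `O=[N+]([O-])c1cc(OCc2ccccc2)ccc1CNc1cc(C(F)(F)F)cc2[nH]ncc12`, > 100000 nM in an assay for inhibition of Indoleamine 2,3-dioxygenase 1 (Homo sapiens), with stated times of 10 min and 60 min; on this read-out lower numbers stand for stronger inhibition and higher numbers for weaker inhibition
- compound 2, `COc1cc(CNc2cc(Br)cc3[nH]ncc23)c([N+](=O)[O-])cc1OC`, 18500 nM in this assay
- compound 3, `O=C(O)CNc1cccc(CNc2cc(C(F)(F)F)cc3[nH]ncc23)c1`, > 100000 nM in this assay

Compound 1 stands at the edge of what this assay can report: its value is a limit, not a number, and it shares that position with compound 3, as the limit of > 100000 nM in this assay, at which 2 of the 3 values shown sit, records. Among the compounds with values here, only compound 2 gives a numerical reading on this read-out, and compound 2 is the one measured compound with a nitro-bearing benzylamine and a numbered result.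

Compound 4, `O=[N+]([O-])c1ccccc1CNc1cc(C(F)(F)F)cc2[nH]ncc12`, is the unmeasured partner of compound 1. The change is hydrogen in place of benzyloxy on an aromatic carbon. Within the data shown here, no step between measured compounds is available to anchor the size of this change, so the expectation rests on the limit of compound 1 and the single number from compound 2. The estimated move an at least 2.5-fold lower number from compound 1 to compound 4 (0.39 log units; beyond the scatter) is toward stronger inhibition, but with broad uncertainty and a real chance of another limit. Compound 4 is expected to give 40000 nM, within 8000 nM to 200000 nM.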

Compound 4, half-maximal inhibitory concentration: 14000 nM
Beside the measured number, compound 4's estimate is 2.9-fold (0.46 log units) above it; low and high end bracket the measured number.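

With hydrogen in place of benzyloxy on this aromatic carbon, meta to a nitro group, this assay gives an at least 7.1-fold lower number from compound 1 to compound 4 (0.85 log units; beyond the scatter). Within the data shown here, this is the first step between compounds that differ in one place, and it shows that the benzyloxy group is not needed for a numerical reading at this position on the shared core. Compound 1 remains a limit and not a number, so the step gives only a minimum size and its full size stays unknown: the limit of > 100000 nM in this assay, at which 2 of the 4 values shown sit.

The compounds shown leave open whether a hydroxyl, a fluorine or an amine on this same carbon would keep the reading of compound 4 or shift it. They also leave open what a nitrile in place of the nitro group would do on this core.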